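The source may report more compounds than this note shows. Statements on the series, on what has been measured and on what is new or still open speak of the compounds shown alone.

Working notes on a small series sharing one core, tested in a functional assay on OVCAR-4 cells (Homo sapiens) for inhibition, read by sulforhodamine B assay, with a stated time of 48 h, tested at 10 uM; on this read-out lower numbers stand for less inhibition of growth and higher numbers for more inhibition of growth at the one concentration tested. Compound 1 `COc1ccc(-c2nc3sc(-c4ccccc4)cn3n2)cc1` gives 37%, and compound 2 `Clc1ccc(-c2cn3nc(-c4ccccc4)nc3s2)cc1` gives 60%. Within the data shown here, compound 2 thus holds the higher of the two numbers so far, and its gap to compound 1 lies beyond the scatter. These two compounds differ in more than one place, so no single-place change has been measured and the data give no direct guide to step size.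

The next compound is compound 3 `COc1ccc(-c2nc3sc(-c4ccc(Cl)cc4)cn3n2)cc1`, which differs from compound 2 by methoxy in place of hydrogen on an aromatic carbon. Compound 3 shares this methoxy with compound 1, which stands at 37%, while it keeps the chlorine-bearing ring of compound 2. A moderate downward step in this assay is therefore expected, although a step within the scatter cannot be ruled out. The estimate corresponds to an expected step of a number 11 percentage points lower from compound 2 to compound 3 (beyond the scatter). The estimated value for compound 3 is 49%, with an expected range of 30% to 68%.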

Compound 3, percent growth inhibition at one concentration: -63.3%
Compound 3: the middle estimate sits 112.3 percentage points above what was measured; the whole stated range lies above it.
By their numbers in this assay, from the lowest: compound 3; then compound 1; then compound 2.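

In this assay, among these compounds, methoxy in place of hydrogen on an aromatic carbon, para to a large group, gives the first single-place reading for this position (a number 123.3 percentage points lower from compound 2 to compound 3 (beyond the scatter)), and it takes the read-out below zero, whereas both earlier compounds gave positive numbers. The second single-place change points the same way: chloro in place of hydrogen on an aromatic carbon gives (a number 100.3 percentage points lower from compound 1 to compound 3 (beyond the scatter)), so in this pair of steps, adding either group to a compound that already carries the other goes with a large fall and not a gain. Nothing at hand accounts for the size of these falls or for the negative number.

The compounds shown leave open how a compound carrying neither methoxy nor chloro would stand, so the separate contribution of each group on the bare core cannot be read. They also leave open whether the fall belongs to methoxy itself or would also follow with hydroxy, an amine, a carboxylic acid or a longer alkoxy chain at the same place.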